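This account rests on a few compounds, and the source may have more. Where it says the series, first, only, none or still open, it means among the compounds named here.

Compound 1 `Cc1ccc(Cn2c(/C=C3\SC(=S)N(CC(=O)O)C3=O)nc3cc(Cl)ccc32)cc1`, compound 2 `Cc1ccc(Cn2c(/C=C3\SC(=S)NC3=O)nc3ccccc32)cc1` and compound 3 `O=C(O)CN1C(=O)/C(=C/c2nc3cc(Cl)ccc3n2Cc2ccccc2F)SC1=S` were examined in a functional assay on MDA-MB-231 cells (Homo sapiens) for cytotoxicity, read by MTT assay, with a stated time of 48 h; a lower number here means a stronger inhibitor, a higher number a weaker inhibitor. In this assay compound 1 gives 13700 nM, compound 2 gives 6420 nM and compound 3 gives 1670 nM. Compound 2 therefore sits between the other two, with a higher number than compound 3 and a lower one than compound 1. The cores of compound 1 and compound 2 are not the same, but the difference between the two cores is not broken down here.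

One change is shared by two pairs. From compound 1 to compound 3 the change is 2-fluorophenyl in place of 4-methylphenyl on a saturated chain carbon bound to an aromatic nitrogen, and it brought a step of an 8.2-fold lower number from compound 1 to compound 3 (0.91 log units; beyond the scatter). The same change, (2-fluorophenyl in place of 4-methylphenyl on a saturated chain carbon bound to an aromatic nitrogen), leads from compound 2 to the still unmeasured compound 4 `O=C1NC(=S)S/C1=C\c1nc2ccccc2n1Cc1ccccc1F`; the place of the change is described in the same words for both pairs, so it is the same change on a different core.

Among the compounds with values here, the step in this assay from compound 2 to compound 4 is expected to be a 3.4-fold lower number from compound 2 to compound 4 (0.53 log units; beyond the scatter), somewhat smaller than the earlier one because the only guide is the single step of an 8.2-fold lower number from compound 1 to compound 3 (0.91 log units; beyond the scatter) measured on a different core. Compound 4 is expected to give about 1900 nM. A range of roughly 700 nM to 5000 nM is expected for compound 4. That expectation rests on the step of an 8.2-fold lower number from compound 1 to compound 3 (0.91 log units; beyond the scatter) and on the value of compound 2, 6420 nM.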

Compound 4, half-maximal inhibitory concentration: 21300 nM
Compound 4: the middle estimate sits 11-fold (1.05 log units) below what was measured; measured number above the stated range.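

In this assay, putting 2-fluorobenzyl in place of 4-methylbenzyl on the core of compound 2 gave a 3.3-fold higher number from compound 2 to compound 4 (0.52 log units; beyond the scatter), so the change did not keep the direction it had on the core of compound 1, and the two steps clearly differ: the same change on two cores in this assay, an 8.2-fold lower number (0.91 log units; beyond the scatter) from compound 1 to compound 3 and a 3.3-fold higher number (0.52 log units; beyond the scatter) from compound 2 to compound 4, 27-fold (1.43 log units) apart, beyond the scatter of two such steps

For this series, then, the effect of this change depends on the core it is placed on, and a gain seen on one core cannot simply be carried to the other. Within the data shown here, this is only one pair on each core, however, so it shows neither why the direction reverses nor how the change would behave on any further core.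

The two cores differ in more than one respect, and the compounds shown do not separate which part of that difference goes with the reversal, leaving open whether either part alone would be enough. They also leave open how an unsubstituted benzyl group, or a benzyl group bearing a methoxy group, would compare with 4-methylbenzyl and 2-fluorobenzyl on each core.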